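Phenyl in place of pyridin-4-yl on the shared core

The compounds below may be only part of what the source reports. "The series", "measured", "known", "first", "only" and "open" are said of these compounds alone.

Measured so far in a functional assay on NCI-H460 cells (Homo sapiens) for inhibition, with a stated time of 72 h; on this read-out lower numbers stand for stronger inhibition and higher numbers for weaker inhibition:
- compound 1 `COc1ccc(S(=O)(=O)N2CCc3cccc(-c4ccc([N+](=O)[O-])cc4)c32)cc1` gives 53.1 nM
- compound 2 `COc1ccc(S(=O)(=O)N2CCc3cccc(-c4ccc(F)c(F)c4)c32)cc1` gives 46 nM
- compound 3 `COc1ccc(S(=O)(=O)N2CCc3cccc(-c4ccncc4)c32)cc1` gives 101 nM

Compound 3 separates clearly from only one of the other two, as the measured steps show: a 1.9-fold higher number from compound 1 to compound 3 (0.28 log units; within the scatter) and a 2.2-fold higher number from compound 2 to compound 3 (0.34 log units; beyond the scatter) in the same read-out. The next compound, compound 4 `COc1ccc(S(=O)(=O)N2CCc3cccc(-c4ccccc4)c32)cc1`, differs from compound 3 in one place (phenyl in place of pyridin-4-yl on an aromatic carbon). Like compounds 1 and 2, it carries a six-membered aromatic ring of carbon only, but its phenyl has no substituent, and no such compound has been measured. The two steps into compound 3 bear most directly on this change, read in reverse. The carbon-only rings themselves stay close, with a 1.2-fold lower number from compound 1 to compound 2 (0.06 log units; within the scatter) as the measured gap. A modest move towards a lower number in this assay is therefore expected, probably not clearly beyond the scatter. The estimated change is a 1.8-fold lower number from compound 3 to compound 4 (0.26 log units; within the scatter) in this direction. Compound 4 is expected near 55 nM (estimated range 25 nM to 120 nM).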

Compound 4, half-maximal inhibitory concentration: 213 nM
For compound 4 the middle estimate is 3.9-fold (0.59 log units) below the measured one; the whole stated range lies below it.
By their numbers in this assay, from the lowest: compounds 2, 1 and 3 (each within the scatter of the next, the first and the last beyond it); then compound 4.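

In this assay the bare phenyl sets itself apart from both substituted carbon-only rings, with a 4.6-fold higher number from compound 2 to compound 4 (0.67 log units; beyond the scatter) and a 4.0-fold higher number from compound 1 to compound 4 (0.60 log units; beyond the scatter) on this aromatic carbon, so a ring of carbon only does not by itself give the lower numbers seen here. The change from pyridin-4-yl to phenyl also raises the number, with a 2.1-fold higher number from compound 3 to compound 4 (0.32 log units; beyond the scatter) in the same read-out, and compound 4 alone among the four has neither a substituent on this ring nor a hetero atom in it. Nothing available explains why the steps run this way.

Going by these compounds, whether a single small group on the phenyl, such as a methyl, a methoxy or an amine, would be enough to bring the number down remains open. So does the outcome with a pyridin-3-yl or a saturated ring such as piperidine at this place.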